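The compounds below may be only part of what the source reports. "The series", "measured", "known", "first", "only" and "open" are said of these compounds alone.

Among the measured compounds shown here, in a functional assay on HCT-15 cells (Homo sapiens) for antiproliferative activity, read by XTT assay (on this read-out lower numbers stand for stronger inhibition and higher numbers for weaker inhibition), compound 1 `O=c1c(Cc2coc3cccc(OCC4CCCCC4)c3c2=O)coc2ccccc12` gives 4240 nM, the only plain number among the three measured compounds. Compound 2 `O=c1c(/C=C/c2coc3ccccc3c2=O)coc2ccccc12` stops at the limit of the assay, > 10000 nM. Compound 3 `O=c1c(Cc2coc3cccc(OCC4CCCCC4)c3c2=O)coc2cc(Cl)ccc12` also stops at a limit, > 10000 nM. For the measured compounds named here, the one comparison that can be counted, an at least 2.3-fold higher number from compound 1 to compound 3 (0.37 log units; beyond the scatter), shows that a chloro in place of hydrogen on an aromatic carbon weakens the compound, with the caveat that two of the three values rest at the limit of > 10000 nM in this assay, at which 2 of the 3 values shown sit. Compound 4 `CC(C)COc1cccc2occ(Cc3coc4ccccc4c3=O)c(=O)c12` differs from compound 1 in another part of the molecule: isopropyl in place of cyclohexyl on a saturated chain carbon bound to an oxygen on an aromatic ring, so that cyclohexylmethoxy becomes isobutoxy. Going by the values given here, no measured step touches this group, and compound 2 alters the linker instead, so nothing measured here fixes the direction of the change. The expected outcome is a step of a 1.4-fold higher number from compound 1 to compound 4 (0.15 log units; within the scatter), with a real chance that only a limit is reported. Compound 4 is therefore estimated at 6000 nM, within 2000 nM to 15000 nM.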

Compound 4, half-maximal inhibitory concentration: > 10000 nM
Compound 4: no number, only a limit; the forecaster's own chance of this, stated with the estimate: 35%; middle value at least 1.6-fold (0.22 log units) away from the limit.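

Among the earlier comparisons, the only one that could be read left the cyclohexylmethoxy group in place, so this is the first readable change to that group. In this assay, among the compounds shown here, the step is an at least 2.3-fold higher number from compound 1 to compound 4 (0.37 log units; beyond the scatter), so exchanging cyclohexyl for isopropyl on this chain carbon weakens the compound beyond the usual scatter, and the ring-bearing compound 1 remains the only one with a plain number. The full size of the loss cannot be fixed because compound 4 stops at a limit: the limit of > 10000 nM in this assay, at which 3 of the 4 values shown sit.

The compounds shown do not separate the loss of the ring from the loss of carbon atoms. They also leave open whether a phenyl group or a longer chain at this place would keep or improve the activity of compound 1.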